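This account rests on a few compounds, and the source may have more. Where it says the series, first, only, none or still open, it means among the compounds named here.

Measured so far in an ADME assay on HepG2 cells (Homo sapiens) for cytotoxicity, read by MTT assay, with a stated time of 48 h; on this read-out lower numbers stand for stronger inhibition and higher numbers for weaker inhibition:
- Compound 1 `O=S(=O)(c1ccc(-c2ccc3ncnc(Nc4ccc(OCc5cccc(F)c5)c(Cl)c4)c3c2)cc1)N1CCCC1`: > 15000 nM
- Compound 2 `CS(=O)(=O)c1cccc(-c2ccc3ncnc(Nc4ccc(OCc5cccc(F)c5)c(Cl)c4)c3c2)c1`: > 15000 nM
- Compound 3 `O=S(=O)(c1ccc(-c2ccc3ncnc(Nc4ccc(OCc5ccccc5)c(Cl)c4)c3c2)cc1)N1CCOCC1`: > 15000 nM

Each of these entries is a limit of the assay and not a number. The three compounds stand together on this evidence: the limit of > 15000 nM in this assay, at which 3 of the 3 values shown sit. Compound 3 therefore has only a limit to its name, > 15000 nM.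

Compound 4 `COc1cccc(COc2ccc(Nc3ncnc4ccc(-c5ccc(S(=O)(=O)N6CCOCC6)cc5)cc34)cc2Cl)c1` departs from compound 3 in one place: methoxy in place of hydrogen on an aromatic carbon. It carries methoxy in place of hydrogen on an aromatic carbon, so that benzyl becomes 3-methoxybenzyl.

Among the measured compounds shown here, no pair of measured compounds differs in one place, so the data offer no step to go by. In this assay, no change beyond the usual scatter is expected, and no direction is favoured. The estimated change is a step that the limit leaves unreadable from compound 3 to compound 4. For compound 4 the estimated value is 20000 nM, with an expected range from 10000 nM to 40000 nM. The assay is expected to report a limit rather than a number.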

Compound 4, half-maximal inhibitory concentration: > 15000 nM
Compound 4: only a limit was reported (the forecaster's own chance of this, stated with the estimate: 85%); the middle value lies beyond the limit too.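

Compound 3 and compound 4 both end at a limit of the assay in this assay, so no step can be read between them: the limit of > 15000 nM in this assay, at which 4 of the 4 values shown sit.

The compounds shown leave open where any of their true values lies, and whether 3-methoxybenzyl in place of benzyl changes the value at all.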